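The source may report more compounds than this note shows. Statements on the series, on what has been measured and on what is new or still open speak of the compounds shown alone.

Compound 3 `COC(=O)c1sc2cc(C#Cc3ccccc3OC)cnc2c1N` carries a 2-methoxyphenyl on the triple-bonded carbon. In a functional assay on MCF7 cells (Homo sapiens) for inhibition, read by sulforhodamine B assay, with a stated time of 48 h (on this read-out lower numbers stand for stronger inhibition of growth and higher numbers for weaker inhibition of growth), compound 3 is reported only as a limit, > 47300 nM. This is the limit of the assay, (the limit of > 47300 nM in this assay, at which 1 of the 3 values shown sits). Among the measured analogues, compound 1 `COC(=O)c1sc2cc(C#Cc3ccccn3)cnc2c1N` gives 37400 nM in this assay, and compound 2 `COC(=O)c1sc2cc(C#Cc3ccc(N)cc3)cnc2c1N` gives 2600 nM. The step of an at least 1.2-fold higher number from compound 1 to compound 3 (0.10 log units; that floor lies within the scatter) is modest, whereas an at least 18-fold higher number from compound 2 to compound 3 (1.25 log units; beyond the scatter) is large. Compound 4 `COC(=O)c1sc2cc(C#Cc3ccccc3)cnc2c1N` differs from compound 3 by hydrogen in place of methoxy on an aromatic carbon. Going by the values given here, no measured step removes a substituent from the aryl group; each measured step exchanges the whole aryl. The closest guide is an at least 1.2-fold higher number from compound 1 to compound 3 (0.10 log units; that floor lies within the scatter), so compound 4 is expected to remain weak, with a step of an at least 1.1-fold lower number from compound 3 to compound 4 (0.07 log units; that floor lies within the scatter) expected. Compound 4 is estimated at 40000 nM, within a range from 10000 nM to 120000 nM.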

Compound 4, concentration for 50% growth inhibition: > 150000 nM
Compound 4: only a limit was reported; the forecaster's own chance of this, stated with the estimate: 45%; middle value at least 3.7-fold (0.57 log units) away from the limit.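

Without the methoxy, compound 4 in this assay is again reported only as a limit, > 150000 nM. The plain phenyl thus separates clearly from the 4-aminophenyl, with an at least 57-fold higher number from compound 2 to compound 4 (1.76 log units; beyond the scatter), and also from the pyridin-2-yl, with an at least 4.0-fold higher number from compound 1 to compound 4 (0.60 log units; beyond the scatter). The step between the two limited compounds, compound 3 and compound 4, cannot be read.

Going by these compounds, whether the methoxy changes growth inhibition at all therefore stays open. So does whether a hydroxyl or a dimethylamino group in place of the amino of compound 2 would keep its stronger reading.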